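Swapping an aryl ether for a phenethyl ether

The source may report more compounds than this note shows. Statements on the series, on what has been measured and on what is new or still open speak of the compounds shown alone.

Compound 1 `CCC1(Cc2ccccc2)OS(=O)(=O)C=C1OCC(=O)OC` gives in an ADME assay on HEL cells (Homo sapiens) for cytotoxicity, with a stated time of 3 days (on this read-out higher numbers stand for lower toxicity in this test and lower numbers for higher toxicity in this test), only a limit, > 200000 nM.
Compound 2 `CCC1(Cc2ccccc2)OS(=O)(=O)C=C1OCc1ccc([N+](=O)[O-])cc1` gives in this assay only a limit, < 200000 nM.
Compound 3 `CCC1(Cc2ccccc2)OS(=O)(=O)C=C1OCc1ccc(C)cc1` gives in this assay the value 41500 nM.

Among the measured compounds shown here, compound 3 therefore stands as the only measured number among the three; the other two sit at a limit, the limit of < 200000 nM in this assay, at which 1 of the 3 values shown sits, and (the limit of > 200000 nM in this assay, at which 1 of the 3 values shown sits). Compound 4 `CCC1(Cc2ccccc2)OS(=O)(=O)C=C1OCCCc1ccccc1` differs from compound 3 in one place: phenethyl in place of 4-methylphenyl on a saturated chain carbon bound to an oxygen on an unsaturated carbon. Of the measured steps, only an at least 4.8-fold lower number from compound 1 to compound 3 (0.68 log units; beyond the scatter) has a readable size; a number no higher from compound 1 to compound 2 (the limit leaves the size open) and a step that the limit leaves unreadable from compound 2 to compound 3 are left open by the limits. None of these steps swaps one aromatic-bearing group for another, so no step beyond the scatter is expected here. Compound 4 is therefore expected to give 40000 nM, between 15000 nM and 120000 nM, a step of a 1.0-fold lower number from compound 3 to compound 4 (0.02 log units; within the scatter).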

Compound 4, half-maximal cytotoxic concentration: 133000 nM
Estimate against measurement, compound 4: 3.3-fold (0.52 log units) below; measured number above the stated range.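

The position does respond to a change between two groups that each carry one six-membered aromatic ring of carbon only: in this assay, phenethyl in place of 4-methylphenyl gives a 3.2-fold higher number from compound 3 to compound 4 (0.51 log units; beyond the scatter) and so lower toxicity in this test. Phenethyl in place of methoxycarbonyl reads as an at least 1.5-fold lower number from compound 1 to compound 4 (0.17 log units; that floor lies within the scatter) and is not a clear change, while the step involving the limit of compound 2 cannot be read. Nothing measured here accounts for the rise with phenethyl.

Still open, as far as these compounds go, is whether a longer chain, such as phenylpropyl, would raise the number further. An amine on the aromatic ring is also untested among the compounds shown.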